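This account rests on a few compounds, and the source may have more. Where it says the series, first, only, none or still open, it means among the compounds named here.

Of the compounds shown here, three sharing one core have been measured in a functional assay on the whole organism (blood, strain Wistar-Okamoto) with Rattus norvegicus as the target, with a stated time of 5 days; a lower number here means that less compound is needed, a higher number that more compound is needed for the effect. Compound 1 `N#CNC(=N)Nc1cccnc1` carries only hydrogen on the double-bonded nitrogen, and in this assay compound 1 gives 50 mg/kg. Compound 2 `CCCCC/N=C(\NC#N)Nc1cccnc1` carries a pentyl group in that place, and in this assay compound 2 gives 20 mg/kg, the lower of the two numbers recorded; compound 1 sits at a higher number, a gap beyond the usual scatter. Compound 3 `CCCCC(CC)C/N=C(\NC#N)Nc1cccnc1` carries a bulkier chain in the same place. In this assay compound 3 reaches only a limit of the assay, > 50 mg/kg, which is not a number (the limit of > 50 mg/kg in this assay, at which 1 of the 3 values shown sits).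

Compound 4 `N#CN/C(=N\C1CC1)Nc1cccnc1` has not yet been measured. It differs from compound 2 in one place: cyclopropyl in place of pentyl on a double-bonded nitrogen. Among the measured compounds shown here, no measured pair shows this exact change, so no step for it is known. Since compound 1 gives 50 mg/kg with hydrogen in that place and compound 2 gives 20 mg/kg with pentyl, a group of intermediate size is expected to land between them, a step of a 1.5-fold higher number from compound 2 to compound 4 (0.18 log units; within the scatter) that may stay within the scatter. Compound 4 is therefore estimated at 30 mg/kg, with a likely range from 12 mg/kg to 80 mg/kg.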

Compound 4, minimum effective dose: 20 mg/kg
For compound 4 the middle estimate is 1.5-fold (0.18 log units) above the measured one, and the stated range covers the measured number.
By their numbers in this assay, from the lowest: compounds 2 and 4 (each within the scatter of the next); then compound 1.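

In this assay, putting cyclopropyl in place of pentyl on the double-bonded nitrogen gives no change at the digits printed from compound 2 to compound 4 (within the scatter). The earlier compounds shown here showed only open chains in this place, whereas this result shows that a closed ring with fewer carbons can serve as well as pentyl, so a long chain is not needed for the lower number. Compound 1, with only hydrogen in that place, gives 50 mg/kg, while compound 4 gives 20 mg/kg, the same number as compound 2.

Going by these compounds, compound 3, with its bulkier chain, reaches only a limit of the assay, so its distance from the others cannot be read: the limit of > 50 mg/kg in this assay, at which 1 of the 4 values shown sits. Still open is how a larger ring such as cyclohexyl, a branched tert-butyl group or a chain ending in an amine would fare in this place.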